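The source may report more compounds than this note shows. Statements on the series, on what has been measured and on what is new or still open speak of the compounds shown alone.

Working notes on the series. In a functional assay on HeLa cells (Homo sapiens) for cytotoxicity, read by MTT assay, with a stated time of 48 h (on this read-out higher numbers stand for weaker inhibition and lower numbers for stronger inhibition), compound 3 (`CCOC(=O)[C@]1(C(=O)Nc2ccccc2)C[C@H]1c1cc(OC)c(OC)c(OC)c1`) reads > 100000 nM and this is a limit, not a number. Compound 1 (`CCOC(=O)C1(C(=O)Nc2ccccc2)CC1c1cc(OC)c(OC)c(OC)c1`) reads > 100000 nM; > 100000 nM (2 entries) across its two entries, again a limit. Going by the values given here, compound 2 (`COc1cc([C@@H]2C[C@]2(CO)C(=O)NCc2ccc(C)cc2)cc(OC)c1OC`) reads 17400 nM as the only true number so far, and it bears 4-methylbenzyl on an amide-type nitrogen.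

Compound 4 (`CCOC(=O)[C@]1(C(=O)NCc2ccc(C)cc2)C[C@H]1c1cc(OC)c(OC)c(OC)c1`) is still unmeasured. Its difference from compound 3 is 4-methylbenzyl in place of phenyl on an amide-type nitrogen. This is a single change, with 4-methylbenzyl in place of phenyl on an amide-type nitrogen. Among the compounds with values here, no measured step isolates this change. Within the data shown here, the only guide is compound 2 at 17400 nM in this assay as the one compound with 4-methylbenzyl and a number. Compounds 1 and 3 carry phenyl and stay at the limit. Compound 2 also differs from compound 4 elsewhere, so this guide is weak. The expected step of an at least 2.5-fold lower number from compound 3 to compound 4 (0.39 log units; beyond the scatter) points to stronger inhibition, and its size is only an estimate, with compound 3 offering no number to count from. Compound 4 is estimated at 40000 nM within an expected range from 12000 nM to 100000 nM and may yet return only a limit.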

Compound 4, half-maximal inhibitory concentration: 28500 nM
For compound 4 the middle estimate is 1.4-fold (0.15 log units) above the measured one; the measured number falls inside the stated range.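

Working notes, continued. In this assay, going by these compounds alone, 4-methylbenzyl in place of phenyl on an amide-type nitrogen gives the first step at this position that leaves the limit of the assay, with an at least 3.5-fold lower number from compound 3 to compound 4 (0.54 log units; beyond the scatter), so the nitrogen substituent matters in the ethoxycarbonyl compounds. Compound 3 stands at a limit, so this step gives a bound and not a full size: the limit of > 100000 nM in this assay, at which 1 of the 4 values shown sits. With 4-methylbenzyl held on the nitrogen, ethoxycarbonyl in place of hydroxymethyl on a saturated ring carbon gives a 1.6-fold higher number from compound 2 to compound 4 (0.21 log units; within the scatter), so this pair shows no separable effect of that change on the read-out in this assay.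

The compounds shown do not tell whether the step at the nitrogen belongs to the methyl on the ring or to the extra carbon linking the ring to the nitrogen, and a plain benzyl or a 4-methylphenyl group on the same nitrogen would separate the two. Also open, from the compounds shown here alone, is how a carboxylic acid or a longer ester such as propoxycarbonyl would read on the same saturated ring carbon.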